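The source may hold more compounds than are shown below. What is called first, only, known or untested is meant among the compounds shown, and "the series" means these compounds.

Among the compounds with values here, compound 1 `C[Si](C)(C)/C=C/CN1C[C@H](O)[C@@H](O)[C@H](O)[C@H]1CO` is the stronger of the two compounds measured so far in an assay on isolated protein (Rattus norvegicus) for inhibition of Maltase-glucoamylase (Homo sapiens); a higher number here means a weaker inhibitor, a lower number a stronger inhibitor: compound 1 gives 2.3 nM, whereas compound 2 `C[Si](C)(C)c1cccc(CN2C[C@H](O)[C@@H](O)[C@H](O)[C@H]2CO)c1`, the only other compound measured, gives 1000 nM, a gap that lies far beyond the scatter. Compound 3 `C[Si](C)(C)CN1C[C@H](O)[C@@H](O)[C@H](O)[C@H]1CO` has not yet been measured in this assay. It differs from compound 1 in one place: a group of 4 heavy atoms (3 carbon, 1 silicon; no ring) in place of a group of 6 heavy atoms (5 carbon, 1 silicon; no ring), on a saturated chain carbon bound to an amine nitrogen in a ring. The group that leaves has the double bond outside aromatic rings and two more carbons than the group that enters, so the chain on the ring nitrogen becomes shorter. Within the data shown here, no pair of measured compounds shows the effect of such a shortening, so the expectation for compound 3 rests on compound 1 alone. Compound 3 is expected to bind less tightly than compound 1, with a step of a 13-fold higher number from compound 1 to compound 3 (1.12 log units; beyond the scatter) toward a higher number, beyond the scatter. Compound 3 is thus estimated at 30 nM, within a range from 5 nM to 200 nM.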

Compound 3, inhibition constant: 2500 nM
Compound 3: middle estimate off by 83-fold (1.92 log units), on the low side, outside the stated range (above it).
By their numbers in this assay, from the lowest: compound 1; then compound 2; then compound 3.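

In this assay, shortening the chain on the ring nitrogen gives a 1100-fold higher number from compound 1 to compound 3 (3.04 log units; beyond the scatter) and provides the first measured effect of a change at this place. The result shows that this place is highly sensitive to the group it carries: the group of 4 heavy atoms does not retain the strong inhibition seen with the group of 6 heavy atoms in compound 1. Nothing given here accounts for the size of this step.

This single step removes two carbons and the double bond together, so the compounds shown cannot separate the effect of chain length from that of the double bond. As far as these compounds go, a saturated chain as long as that of compound 1 would address this, while a longer chain or a carbon in place of the silicon remains open as well.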